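Dichlorophenyl pattern swap: from compound 3 to compound 4

A few compounds are considered here, and "the series" means these few. Any claim that something is new, unique, unknown or untested is made for them only; others in the source may bear on it.

Numbers so far in a functional assay on MNK45 cells (Homo sapiens) for inhibition, read by MTT assay, with a stated time of 48 h (on this read-out higher numbers stand for weaker inhibition and lower numbers for stronger inhibition), for the three measured compounds:

compound 1 `Cc1ccc(NC(=S)NC(=O)c2ccc(OCc3cccc(Cl)c3)cc2)cc1-c1nc2ccccc2[nH]1`: 43300 nM
compound 2 `Cc1ccc(NC(=S)NC(=O)c2ccc(OCc3ccccc3F)cc2)cc1-c1nc2ccccc2[nH]1`: 2420 nM
compound 3 `Cc1ccc(NC(=S)NC(=O)c2ccc(OCc3ccc(Cl)c(Cl)c3)cc2)cc1-c1nc2ccccc2[nH]1`: 8410 nM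

Compound 3 stands second highest of the three numbers; its nearest neighbour is compound 2 and its furthest is compound 1. The measured steps are an 18-fold lower number from compound 1 to compound 2 (1.25 log units; beyond the scatter), a 3.5-fold higher number from compound 2 to compound 3 (0.54 log units; beyond the scatter) and a 5.1-fold lower number from compound 1 to compound 3 (0.71 log units; beyond the scatter).

Compound 4 `Cc1ccc(NC(=S)NC(=O)c2ccc(OCc3ccc(Cl)cc3Cl)cc2)cc1-c1nc2ccccc2[nH]1` is not yet measured in this assay. It differs from compound 3 in one place: 2,4-dichlorophenyl in place of 3,4-dichlorophenyl on a saturated chain carbon bound to an oxygen on an aromatic ring. Among the measured compounds shown here, no measured step bears directly on moving one chlorine within a dichlorophenyl. The closest are an 18-fold lower number from compound 1 to compound 2 (1.25 log units; beyond the scatter) and a 3.5-fold higher number from compound 2 to compound 3 (0.54 log units; beyond the scatter), both changes at the same saturated chain carbon bound to an oxygen, and in both the 2-fluorophenyl compound 2 gave the lowest number with 2420 nM. On that basis a modestly lower number than compound 3 is expected, a 2.1-fold lower number from compound 3 to compound 4 (0.32 log units; beyond the scatter), with wide uncertainty. Compound 4 is estimated at 4000 nM in this assay, within a range from 1500 nM to 12000 nM.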

Compound 4, half-maximal inhibitory concentration: 5300 nM
Compound 4: the middle estimate sits 1.3-fold (0.12 log units) below what was measured, within the range that was stated.
By their numbers in this assay, from the lowest: compound 2; then compounds 4 and 3 (each within the scatter of the next); then compound 1.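

In this assay, the 2,4-dichlorophenyl and 3,4-dichlorophenyl groups on the saturated chain carbon bound to an oxygen on an aromatic ring are not told apart by this change of chlorine pattern (a 1.6-fold lower number from compound 3 to compound 4 (0.20 log units; within the scatter)). Among the compounds shown here, compound 4 nevertheless stays separated beyond the scatter from the 2-fluorophenyl group (a 2.2-fold higher number from compound 2 to compound 4 (0.34 log units; beyond the scatter)) and from the 3-chlorophenyl group (an 8.2-fold lower number from compound 1 to compound 4 (0.91 log units; beyond the scatter)), so the single chlorine of compound 1 is set apart from both dichlorophenyl patterns, and compound 2 keeps the lowest number of the four. Nothing available accounts for these differences.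

Still open, as far as these compounds go, is whether the halogens are needed at all, as an unsubstituted phenyl would show. Also open, from the compounds shown here alone, is how a carboxylic acid or an amine on this ring would read in this assay.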